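This account rests on a few compounds, and the source may have more. Where it says the series, first, only, none or still open, it means among the compounds named here.

Going by the values given here, compound 2 `NC(N)=NC(=O)c1nc(Cl)c(NCc2cccc(F)c2)nc1N` is one of two compounds measured in an assay for inhibition of acid-sensing ion channel 3 (Homo sapiens), read by patch clamp, tested at 20 uM (a lower number here means less inhibition, a higher number more inhibition at the concentration tested (going by the name of the read-out)), where compound 2 gives 90%. Compound 1 `NC(N)=NC(=O)c1nc(Cl)c(NCc2ccc(Cl)cc2)nc1N` gives 97% in this assay, and the step of a number 7 percentage points lower from compound 1 to compound 2 (within the scatter) leaves the two values within the scatter of each other, so compound 2 stands level with compound 1 rather than apart from it. Compound 3 `NC(N)=NC(=O)c1nc(Cl)c(NCc2ccccc2F)nc1N` has not been measured and differs from compound 2 by 2-fluorophenyl in place of 3-fluorophenyl on a saturated chain carbon bound to a nitrogen on an aromatic ring. Among the compounds with values here, only one measured step bears on this change, a number 7 percentage points lower from compound 1 to compound 2 (within the scatter), which also exchanged the ring group on that carbon and stayed within the scatter. For compound 3 the expected step is therefore a number 2 percentage points lower from compound 2 to compound 3 (within the scatter), nothing beyond the scatter. Compound 3 is estimated at 88%, between 75% and 98%.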

Compound 3, a percentage reported as inhibition, at one concentration (the size of the read-out at that concentration, not a potency): 92%
Compound 3: middle estimate off by 4 percentage points, on the low side; the measured number falls inside the stated range.
By their numbers in this assay, from the lowest: compounds 2, 3 and 1 (each within the scatter of the next).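

Moving the fluorine around the ring in this assay gives no separation (a number 2 percentage points higher from compound 2 to compound 3 (within the scatter)), and neither does exchanging the ring group for 2-fluorophenyl (a number 5 percentage points lower from compound 1 to compound 3 (within the scatter)). On the saturated chain carbon, 2-fluorophenyl therefore reads level with both 3-fluorophenyl and 4-chlorophenyl, so the place of the fluorine makes no difference beyond the scatter in these compounds. Nothing available bears on why these values stand level. Still open, as far as these compounds go, is whether a ring carrying a methoxy group, or a cyclohexyl group or longer carbon chain in place of the ring, would read the same. Each number also comes from a single concentration, so any difference in potency among these compounds remains unknown.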